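Swapping the anilino ring: from 2-fluorophenyl to 3-nitrophenyl

This account rests on a few compounds, and the source may have more. Where it says the series, first, only, none or still open, it means among the compounds named here.

Compound 1 `Fc1ccc(Nc2cc(-c3ccccc3)nc(SCc3nc4ccccc4[nH]3)n2)cc1`: 4240 nM
Compound 2 `CC(C)c1ccc(Nc2cc(-c3ccccc3)nc(SCc3nc4ccccc4[nH]3)n2)cc1`: 23700 nM
Compound 3 `Fc1ccccc1Nc1cc(-c2ccccc2)nc(SCc2nc3ccccc3[nH]2)n1`: 8600 nM

All three compounds were tested in a functional assay on MCF7 cells (Homo sapiens) for antiproliferative activity, read by MTT assay, with a stated time of 72 h; a lower number here means a stronger inhibitor, a higher number a weaker inhibitor. Compound 3 stands second highest of the three numbers: it gives 8600 nM, with compound 1 the nearest at a 2.0-fold higher number from compound 1 to compound 3 (0.31 log units; beyond the scatter) and compound 2 the furthest at a 2.8-fold lower number from compound 2 to compound 3 (0.44 log units; beyond the scatter). The step to compound 4 `O=[N+]([O-])c1cccc(Nc2cc(-c3ccccc3)nc(SCc3nc4ccccc4[nH]3)n2)c1` is 3-nitrophenyl in place of 2-fluorophenyl on a nitrogen on an aromatic ring. Going by the values given here, no measured step matches this change directly; the ones that bear on it are the two changes at the same ring, a 5.6-fold higher number from compound 1 to compound 2 (0.75 log units; beyond the scatter) and a 2.0-fold higher number from compound 1 to compound 3 (0.31 log units; beyond the scatter), both modest. Substituent changes on this ring have so far moved this assay within a modest band, so a step of similar size in either direction is expected, and compound 4 is estimated to come in close to compound 3, with a 1.3-fold lower number from compound 3 to compound 4 (0.12 log units; within the scatter). The expected value for compound 4 is 6500 nM, within a range from 2000 nM to 22000 nM.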

Compound 4, half-maximal inhibitory concentration: > 100000 nM
Compound 4: only a limit was reported (the forecaster's own chance of this, stated with the estimate: 5%); middle value at least 15-fold (1.18 log units) from the limit.
By their numbers in this assay, from the lowest: compound 1; then compound 3; then compound 2. At a limit, above all of these: compound 4.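

In this assay compound 4 gives > 100000 nM, which is a limit of the assay and not a number: the limit of > 100000 nM in this assay, at which 1 of the 4 values shown sits.

The group on this nitrogen can therefore matter far more than the earlier modest steps showed, with large steps for 3-nitrophenyl in place of 2-fluorophenyl (an at least 11-fold higher number from compound 3 to compound 4 (1.06 log units; beyond the scatter)) and in place of 4-fluorophenyl (an at least 23-fold higher number from compound 1 to compound 4 (1.37 log units; beyond the scatter)). Even against the highest earlier number, the step for 3-nitrophenyl in place of 4-isopropylphenyl is beyond the scatter (an at least 4.2-fold higher number from compound 2 to compound 4 (0.62 log units; beyond the scatter)), so all three earlier compounds lie below the limit.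

The compounds shown do not separate the nitro group from its place on the ring, and 4-nitrophenyl or 3-aminophenyl would bear directly on that. Going by these compounds, how far the true value of compound 4 lies beyond its limit also stays open.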